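The compounds below may be only part of what the source reports. "The series", "measured", "known", "first", "only" and "open" are said of these compounds alone.

Three compounds have been measured in an ADME assay on microsomes from liver (Mus musculus) for metabolic stability; a higher number here means that the compound lasts longer, a lower number that the compound disappears faster:

- compound 1 `CCC(CC)(c1nnc[nH]1)c1ccc(-c2ccc3cc(F)cc(F)c3c2)[nH]c1=O` gives 1.09 h
- compound 2 `CC(C)C(Cc1ncc[nH]1)c1ccc(-c2ccc3cccc(F)c3c2)[nH]c1=O` gives < 0.0667 h (a limit)
- compound 3 `CC(C)C(c1ncco1)c1ccc(-c2ccc3cccc(F)c3c2)[nH]c1=O` gives 0.08 h

Compound 1 holds the higher of the two actual numbers, at 1.09 h, and compound 3 gives 0.08 h, a gap well beyond the scatter. Compound 2 has no number, only a limit, as the limit of < 0.0667 h in this assay, at which 1 of the 3 values shown sits, records.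

Compound 4 `CCC(CC)(c1nnc[nH]1)c1ccc(-c2ccc3cccc(F)c3c2)[nH]c1=O` differs from compound 1 in one place, hydrogen in place of fluoro on an aromatic carbon. Among the compounds with values here, no measured step isolates this change. Within the data shown here, the only step available, an at least 1.1-fold higher number from compound 2 to compound 3 (0.07 log units; that floor lies within the scatter), alters the chain and leaves the fluoro pattern untouched, so it gives no size for this replacement. Like compound 4, compound 3 has hydrogen at that place and gives 0.08 h, but it also differs from compound 1 in the chain, so its low number cannot be credited to the fluoro alone. It does leave some risk on the low side. With compound 1 at 1.09 h as the anchor, a small drop is expected, no larger than the scatter. The expected change is a 1.5-fold lower number from compound 1 to compound 4 (0.16 log units; within the scatter). For compound 4 the estimate is 0.75 h, with an expected range from 0.25 h to 1.6 h.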

Compound 4, half-life: 0.447 h
Estimate against measurement, compound 4: 1.7-fold (0.22 log units) above; the range from low to high includes it.
By their numbers in this assay, from the lowest: compound 3; then compound 4; then compound 1. At a limit, below all of these: compound 2.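

In this assay, within the data shown here, the replacement of this fluoro by hydrogen gives a 2.4-fold lower number from compound 1 to compound 4 (0.39 log units; beyond the scatter), the first step that isolates this position, and it shows that the position is not silent: on an otherwise unchanged compound, a single atom on an aromatic carbon, meta to a fluoro group, moves the half-life by more than the usual scatter. Among these compounds, the earlier compounds could not show this, since the only step among them alters the chain and leaves the fluoro pattern untouched, so the size of this change can now be stated for the first time, though it rests on this one pair alone and the step is modest. Nothing measured here explains why this fluoro matters, and the available evidence has no bearing on this step.

From the compounds shown here alone, whether the same replacement has a similar size with the chain of compound 3, which carries hydrogen at this place, remains open. Also open, going by these compounds, is how a chloro, a methoxy or a nitrile at this position would compare with fluoro and hydrogen.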